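Methylation of a Phenolic Hydroxyl in Triazolylhydrazones

The source may hold more compounds than are shown below. What is called first, only, known or untested is meant among the compounds shown, and "the series" means these compounds.

Compound 1 `Oc1cccc(/C=N/n2cnnc2)c1O` gives in a functional assay on PC-3 cells (Homo sapiens) for cytotoxicity (on this read-out lower numbers stand for stronger inhibition and higher numbers for weaker inhibition), a value of > 30000 nM, which is a limit of the assay.
Compound 2 `Oc1ccc(/C=N/n2cnnc2)cc1` gives > 30000 nM, also a limit.
Compound 3 `COc1cccc(/C=N/n2cnnc2)c1O` gives > 30000 nM, again a limit.

From compound 1 to compound 3 the change is methyl in place of hydrogen on an oxygen on an aromatic ring. The step that the two limits leave unreadable from compound 1 to compound 3 cannot be read, since both values sit at the limit of > 30000 nM in this assay, at which 3 of the 3 values shown sit. How the core of compound 1 differs from that of compound 2 is not broken down here. Compound 4 `COc1ccc(/C=N/n2cnnc2)cc1` has not yet been measured in this assay; from compound 2 it differs by methyl in place of hydrogen on an oxygen on an aromatic ring, the same change as from compound 1 to compound 3. The step that the limit leaves unreadable from compound 2 to compound 4 is expected to be small, resting on the three limits already seen. Compound 4 is estimated at 40000 nM, between 12000 nM and 150000 nM.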

Compound 4, half-maximal inhibitory concentration: > 30000 nM
Compound 4: no number, only a limit; the forecaster's own chance of this, stated with the estimate: 85%; the middle value does not contradict the limit.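

No step can be read from compound 2 to compound 4 in this assay, since both values are limits: the limit of > 30000 nM in this assay, at which 4 of the 4 values shown sit.

The compounds shown leave open how large the change from hydroxy to methoxy is in this assay.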